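Hydroxycarbamoyl in place of hydroxymethyl on compound 3

The source may report more compounds than this note shows. Statements on the series, on what has been measured and on what is new or still open speak of the compounds shown alone.

Measured in a physicochemical assay for solubility, read by HPLC, at pH 7.4; on this read-out higher numbers stand for higher solubility and lower numbers for lower solubility
Compound 1 `CCOCCCCc1cc(=O)c2ccccc2[nH]1` gives > 200000 nM
Compound 2 `CCCCCCCc1[nH]c2ccccc2c(=O)c1CO` gives 50000 nM
Compound 3 `CCCCCCCc1[nH]c2ccc([N+](=O)[O-])cc2c(=O)c1CO` gives 5000 nM

The entry for compound 1 is a limit of the assay and not a number. Among the two true numbers, compound 3 stands lowest, and its only neighbour is compound 2.

Compound 4 `CCCCCCCc1[nH]c2ccc([N+](=O)[O-])cc2c(=O)c1C(=O)NO` carries hydroxycarbamoyl in place of hydroxymethyl on an aromatic carbon, ortho to a heptyl group: hydroxycarbamoyl in place of hydroxymethyl on an aromatic carbon.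

For the measured compounds named here, only one measured step is available: a 10-fold lower number from compound 2 to compound 3 (1.00 log units; beyond the scatter). That step is nitro in place of hydrogen on an aromatic carbon, so it concerns a different place and different groups. It shows that this series can move beyond the scatter with a single change, but it gives no size or direction for the present exchange. Going by the values given here, no measured step involves the hydroxymethyl group.

No step beyond the scatter is therefore expected in this assay, and no direction is favoured with any confidence. The expected change is a 1.2-fold higher number from compound 3 to compound 4 (0.08 log units; within the scatter), and the range is kept wide. For compound 4 the estimated value is 6000 nM, with an expected range of 1500 nM to 25000 nM.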

Compound 4, solubility: > 200000 nM
Compound 4 was reported as a limit; the forecaster's own chance of this, stated with the estimate: 5%; middle value at least 33-fold (1.52 log units) away from the limit.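

At this place on the core, two atoms from the ring nitrogen, the exchange of hydroxymethyl for hydroxycarbamoyl gives an at least 40-fold higher number from compound 3 to compound 4 (1.60 log units; beyond the scatter) in this assay, so the group held here can move this read-out well beyond the scatter even with the nitro group kept on the core. The only earlier step, a 10-fold lower number from compound 2 to compound 3 (1.00 log units; beyond the scatter), lay at another place and ran the opposite way on this read-out, so this position is the first shown to raise the number. Compound 4 carries a limit of the assay and not a number, > 200000 nM, and the full size of the exchange therefore stays unread, with the scale closing at that value for this series: the limit of > 200000 nM in this assay, at which 2 of the 4 values shown sit.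

The compounds shown leave open whether the whole hydroxycarbamoyl group is needed here, and a carboxylic acid or a primary amide at this place would test that. Also open, going by these compounds, is whether the exchange carries over to the core without the nitro group, or to a shorter chain in place of the heptyl group.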